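Moving Two Chlorines: From 2,3-Dichlorobenzyl to 3,5-Dichlorobenzyl

The source may report more compounds than this note shows. Statements on the series, on what has been measured and on what is new or still open speak of the compounds shown alone.

Compound 1 `Cc1cccc(CNC(=O)C(=O)N[C@@H](C)C(=O)N[C@@H](CC(=O)O)C(=O)COc2c(F)c(F)cc(F)c2F)c1C` gives 102 nM
Compound 2 `C[C@H](NC(=O)C(=O)NCc1cccc(Cl)c1Cl)C(=O)N[C@@H](CC(=O)O)C(=O)COc1c(F)c(F)cc(F)c1F` gives 76 nM

In a functional assay on Jurkat cells (Homo sapiens) (a lower number here means a stronger inhibitor, a higher number a weaker inhibitor), compound 2 gives 76 nM and cannot be told apart from compound 1. Compound 3 `C[C@H](NC(=O)C(=O)NCc1cc(Cl)cc(Cl)c1)C(=O)N[C@@H](CC(=O)O)C(=O)COc1c(F)c(F)cc(F)c1F` has the same atoms as compound 2, joined differently: 3,5-dichlorophenyl in place of 2,3-dichlorophenyl on a saturated chain carbon bound to an amide-type nitrogen. Among the measured compounds shown here, the only measured step is a 1.3-fold lower number from compound 1 to compound 2 (0.13 log units; within the scatter) and it exchanges 2,3-dimethylphenyl for 2,3-dichlorophenyl. For the measured compounds named here, no measured compound carries 3,5-dichlorophenyl, so that step offers only weak guidance. No change beyond the scatter is expected in either direction in this assay, though the uncertainty is wide. The expected change is a 1.2-fold higher number from compound 2 to compound 3 (0.07 log units; within the scatter). For compound 3 the estimate is 90 nM with an expected range from 35 nM to 230 nM.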

Compound 3, half-maximal inhibitory concentration: 23 nM
The estimate for compound 3 lay 3.9-fold (0.59 log units) above the measured number; measured number below the stated range.
By their numbers in this assay, from the lowest: compound 3; then compounds 2 and 1 (each within the scatter of the next).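

Within this assay this position responds to where the two chlorines sit and not just to their presence: with the same atoms, moving to the 3,5-dichlorobenzyl group gives a 3.3-fold lower number from compound 2 to compound 3 (0.52 log units; beyond the scatter) and is the first change here beyond the scatter. Set against the 2,3-dimethylphenyl group, it gives a 4.4-fold lower number from compound 1 to compound 3 (0.65 log units; beyond the scatter) and leaves compound 3 the strongest inhibitor of the three. Nothing measured here accounts for the difference. On these data alone, whether a single chlorine, or trifluoromethyl or methoxy groups in place of the chlorines, would match compound 3 stays open.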